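Swapping 4-butoxyphenyl for 2-methylphenyl in an antiproliferative series

A few compounds are considered here, and "the series" means these few. Any claim that something is new, unique, unknown or untested is made for them only; others in the source may bear on it.

Three compounds with a shared core are in view here, and two of them have been tested in a functional assay on A549 cells (Homo sapiens) for antiproliferative activity, read by MTT assay, with a stated time of 24 h; on this read-out higher numbers stand for weaker inhibition and lower numbers for stronger inhibition. Among the measured compounds shown here, in that test compound 2 `CCCCOc1ccc(C(=O)NNC(=O)c2ccccc2NS(=O)(=O)c2cnc(O)nc2O)cc1` gives 4960 nM, the only true number so far. Compound 1 `Cc1cccc(NNC(=O)c2ccccc2NS(=O)(=O)c2cnc(O)nc2O)c1` returns only a limit of the assay, > 20000 nM. Compound 2 therefore has no other number to be ranked against.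

Compound 3 `Cc1ccccc1C(=O)NNC(=O)c1ccccc1NS(=O)(=O)c1cnc(O)nc1O` has not yet been measured. It keeps the shared core of compound 2 and differs at one place, on a carbonyl carbon whose other neighbour is an amide-type nitrogen: 2-methylphenyl in place of 4-butoxyphenyl on a carbonyl carbon. In words, 2-methylphenyl stands in place of 4-butoxyphenyl.

For the measured compounds named here, no measured step between compounds differing in one place is available, so the size of this change can only be judged loosely. The judgement leans on compound 1, which also lacks the butoxy chain and whose > 20000 nM is a limit. Weaker inhibition in this assay is expected, with an estimated change of a 2.6-fold higher number from compound 2 to compound 3 (0.42 log units; beyond the scatter). For compound 3 the expected value is 13000 nM, within an estimated range of 5000 nM to 32000 nM.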

Compound 3, half-maximal inhibitory concentration: 5450 nM
Beside the measured number, compound 3's estimate is 2.4-fold (0.38 log units) above it; the range from low to high includes it.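

In this assay, the exchange of 4-butoxyphenyl for 2-methylphenyl on a carbonyl carbon gives a 1.1-fold higher number from compound 2 to compound 3 (0.04 log units; within the scatter), so the butoxy chain is not required for the activity of compound 2 at this position. The other new comparison gives an at least 3.6-fold lower number from compound 1 to compound 3 (0.56 log units; beyond the scatter), which shows that lacking the butoxy chain does not by itself set compound 1 apart, since compound 3 lacks it too; what separates them is (2-methylphenyl)carbonyl in place of 3-methylphenyl on an amine nitrogen. The value of compound 1 is a limit, and that step can therefore be read only as a minimum: the limit of > 20000 nM in this assay, at which 1 of the 3 values shown sits.

The compounds shown leave open whether the carbonyl itself or the shift from 3-methylphenyl to 2-methylphenyl accounts for that step, as the two changes come together in this one comparison. Going by these compounds, it also stays open how a carboxylic acid or an amine on the phenyl ring, in place of the methyl or butoxy group, would read in this assay.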